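Aryl ether variation in a thromboxane synthase inhibitor series

The source may hold more compounds than are shown below. What is called first, only, known or untested is meant among the compounds shown, and "the series" means these compounds.

Compound 1 `O=C(O)CC/C=C\CC1COC(c2ccsc2)OC1c1cccnc1` is the simpler member of the pair measured. In an assay for inhibition of Thromboxane-A synthase (Homo sapiens), using microsomes (a lower number here means a stronger inhibitor, a higher number a weaker inhibitor), compound 1 gives 500 nM. Compound 2 `Cc1ccc(C#N)c(OC(C)(C)C2OCC(C/C=C\CCC(=O)O)C(c3cccnc3)O2)c1` instead bears a branched ether carrying 2-cyano-5-methylphenyl on the shared core, and in this assay compound 2 gives 50 nM, the lower of the two numbers; the gap to compound 1 lies beyond the usual scatter. Compound 3 `COc1ccc(OC(C)(C)C2OCC(C/C=C\CCC(=O)O)C(c3cccnc3)O2)c([N+](=O)[O-])c1` keeps the core and ether of compound 2 and alters only the aryl group: 4-methoxy-2-nitrophenyl in place of 2-cyano-5-methylphenyl on an oxygen on a saturated carbon. Within the data shown here, no measured pair isolates this change, so its size is not known from the data. Both aryl groups keep a six-membered ring of carbon only on the same oxygen, and the change is expected to move the number only modestly, as a step of a 1.6-fold higher number from compound 2 to compound 3 (0.20 log units; within the scatter) that stays within or near the scatter. Compound 3 is therefore expected to give 80 nM, with a range of 30 nM to 250 nM.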

Compound 3, half-maximal inhibitory concentration: 37 nM
Estimate against measurement, compound 3: 2.2-fold (0.33 log units) above; the range from low to high includes it.
By their numbers in this assay, from the lowest: compounds 3 and 2 (each within the scatter of the next); then compound 1.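

In this assay, among these compounds, the exchange of 2-cyano-5-methylphenyl for 4-methoxy-2-nitrophenyl on an oxygen on a saturated carbon gives a 1.4-fold lower number from compound 2 to compound 3 (0.13 log units; within the scatter), the first measured step at this position. The aryl group on this oxygen can therefore be exchanged for one with more heavy atoms and more hydrogen-bond acceptors, and with a nitro group and methoxy in place of nitrile and methyl, without a difference that can be read in this assay. No available evidence bears on why these two aryl groups read alike.

Both substituents change together in this step, so the part played by each one alone stays unresolved. Also open, on these data alone, is how the number responds to an unsubstituted phenyl, a saturated cyclohexyl ring or an amine in place of the oxygen.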